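Halogenated aryl in place of the aminophenyl on the triazole

A few compounds are considered here, and "the series" means these few. Any claim that something is new, unique, unknown or untested is made for them only; others in the source may bear on it.

Compound 1 `Cc1cccc(-n2nncc2CN2C(=O)C3(C(C#N)=C(N)Oc4c3c3nc5ccccc5nc3c3ccccc43)c3ccccc32)c1`: in a functional assay on HCT-116 cells (Homo sapiens) for antiproliferative activity, read by MTT assay, with a stated time of 48 h (a lower number here means a stronger inhibitor, a higher number a weaker inhibitor), compound 1 gives > 50000 nM, a limit of the assay.
Compound 2 `N#CC1=C(N)Oc2c(c3nc4ccccc4nc3c3ccccc23)C12C(=O)N(Cc1cnnn1-c1ccc(F)cc1)c1ccccc12`: in this assay compound 2 gives > 50000 nM, again a limit.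
Compound 3 `N#CC1=C(N)Oc2c(c3nc4ccccc4nc3c3ccccc23)C12C(=O)N(Cc1cnnn1-c1ccc(N)cc1)c1ccccc12`: in this assay compound 3 gives 45200 nM.

Compound 3 is the only one of the three with a read number; the other two sit at the limit, as the evidence the limit of > 50000 nM in this assay, at which 2 of the 3 values shown sit, records. Compound 4 `Cc1ccc(-n2nncc2CN2C(=O)C3(C(C#N)=C(N)Oc4c3c3nc5ccccc5nc3c3ccccc43)c3ccccc32)cc1Cl` differs from compound 3 in one place: 3-chloro-4-methylphenyl in place of 4-aminophenyl on an aromatic nitrogen. Among the measured compounds shown here, two measured steps bear on this change. The step of an at least 1.1-fold lower number from compound 1 to compound 3 (0.04 log units; that floor lies within the scatter) and the step of an at least 1.1-fold lower number from compound 2 to compound 3 (0.04 log units; that floor lies within the scatter) both run toward the aminophenyl, and each is only a floor set by a limit. Compound 4 moves away from the aminophenyl toward an aryl carrying chloro and methyl, a direction for which compounds 1 and 2 give only limits. No step beyond the scatter is therefore expected; compound 4 is expected to land at or near the limit, giving an estimated step of a 1.2-fold higher number from compound 3 to compound 4 (0.09 log units; within the scatter). The estimate for compound 4 in this assay is 55000 nM, within a range from 30000 nM to 120000 nM.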

Compound 4, half-maximal inhibitory concentration: > 50000 nM
Compound 4: a limit, no number; the forecaster's own chance of this, stated with the estimate: 70%; the middle value does not contradict the limit.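

With a 3-chloro-4-methylphenyl on the aromatic nitrogen, a third aryl without an amino group joins the 3-methylphenyl of compound 1 and the 4-fluorophenyl of compound 2 at the limit, so placing chloro and methyl together on the ring gives no read number where neither a single methyl nor a single fluoro did. Among the compounds shown here, the one step that can be read is an at least 1.1-fold higher number from compound 3 to compound 4 (0.04 log units; that floor lies within the scatter), so even this further comparison does not separate the 4-aminophenyl of compound 3 from the aryl groups lacking an amino group, and the steps among compound 1, compound 2 and compound 4 cannot be read at all. All three compounds without the amino group now stand at the same limit, compound 3 alone going against that pattern, and the series offers little room for comparison: the limit of > 50000 nM in this assay, at which 3 of the 4 values shown sit.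

On these data alone, whether a hydroxyl, a methoxy or a dimethylamino group in place of the amino group would also give a read number stays open. So does what a carboxylic acid on the phenyl, or a cyclohexyl in place of the aryl, would do in this assay.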